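The source may report more compounds than this note shows. Statements on the series, on what has been measured and on what is new or still open speak of the compounds shown alone.

Three compounds sharing one core have numbers in a functional assay on MCF7 cells (Homo sapiens) for cytotoxicity, read by MTT assay; a lower number here means a stronger inhibitor, a higher number a weaker inhibitor. Compound 1 `Oc1ccc(CN(Cc2ccccc2C(F)(F)F)Cc2ccc(O)c3ncccc23)c2cccnc12` gives 88 nM, compound 2 `Oc1ccc(CN(Cc2cccc(C(F)(F)F)c2)Cc2ccc(O)c3ncccc23)c2cccnc12` gives 30 nM, and compound 3 `Oc1ccc(CN(Cc2cccc(I)c2)Cc2ccc(O)c3ncccc23)c2cccnc12` gives 374 nM. Compound 3 therefore has the highest number of the three and is the weakest inhibitor among them, with its steps to both others beyond the scatter.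

The next compound, compound 4 `Oc1ccc(CN(Cc2cccs2)Cc2ccc(O)c3ncccc23)c2cccnc12`, carries thiophen-2-yl in place of 3-iodophenyl on a saturated chain carbon bound to an amine nitrogen. For the measured compounds named here, no measured step makes this exchange, so the evidence is indirect. The measured steps show only how far changes at this place have moved the number. a 2.9-fold lower number from compound 1 to compound 2 (0.47 log units; beyond the scatter) was modest, a 4.3-fold higher number from compound 1 to compound 3 (0.63 log units; beyond the scatter) was also modest, and a 12-fold higher number from compound 2 to compound 3 (1.10 log units; beyond the scatter) was large. The last of these shows that a single substituent swap on the aromatic ring can matter greatly in this series.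

Going by the values given here, with compound 3 at 374 nM, the top of the measured range, a modest move towards a lower number is expected, though the data hold no thiophen-2-yl example to confirm it. The expected change is a 2.5-fold lower number from compound 3 to compound 4 (0.40 log units; beyond the scatter). For compound 4 the estimated value is 150 nM, with an expected range of 45 nM to 450 nM.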

Compound 4, half-maximal inhibitory concentration: 35 nM
Estimate against measurement, compound 4: 4.3-fold (0.63 log units) above; measured number outside the range, below it.
By their numbers in this assay, from the lowest: compounds 2 and 4 (each within the scatter of the next); then compound 1; then compound 3.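

In this assay the result shows that the group on this saturated chain carbon bound to an amine nitrogen need not be a six-membered aromatic ring of carbon only: exchanging 3-iodophenyl for thiophen-2-yl gives an 11-fold lower number from compound 3 to compound 4 (1.03 log units; beyond the scatter) and so removes most of the loss seen with the iodo group. The five-membered ring with 1 hetero atom also holds its own against the best phenyl group shown, since the exchange for 3-(trifluoromethyl)phenyl gives a 1.2-fold higher number from compound 2 to compound 4 (0.07 log units; within the scatter) and leaves the two groups indistinguishable here. Against 2-(trifluoromethyl)phenyl the same exchange gives a 2.5-fold lower number from compound 1 to compound 4 (0.40 log units; beyond the scatter) as a step in the same direction, so among the four compounds only the two substituted phenyl groups, 2-(trifluoromethyl)phenyl and 3-iodophenyl, stand clearly on the weaker side of thiophen-2-yl. Nothing available explains why these exchanges move the number as they do.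

The compounds shown leave open whether the sulfur atom matters, as thiophen-3-yl, furan-2-yl and unsubstituted phenyl do not appear among them. They also leave open how this position would respond to a ring carrying an amine or a carboxylic acid.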